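The compounds below may be only part of what the source reports. "The series", "measured", "known", "first", "only" and "open" are said of these compounds alone.

Measured so far: compound 1 `Cc1noc(NS(=O)(=O)c2cccc3c(NC(C)C)cccc23)c1C` gives 5 nM; compound 2 `Cc1noc(NS(=O)(=O)c2cccc3ccc(N(C)C)cc23)c1C` gives 5600 nM; compound 3 `Cc1noc(NS(=O)(=O)c2ccc3cccc(N)c3c2)c1C` gives 9800 nM.

All three were tested in an assay on thoracic aorta for binding affinity to Endothelin-1 receptor (Rattus norvegicus); a lower number here means a stronger inhibitor, a higher number a weaker inhibitor. Compound 3 has the highest number of the three. Its nearest neighbour is compound 2, whose number is within the scatter of it, so the two cannot be told apart. Compound 1 is far away, beyond the scatter. Within the data shown here, no two measured compounds differ in only one place, so no single step is known from them.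

Compound 4 `CC(=O)Nc1cccc2ccc(S(=O)(=O)Nc3onc(C)c3C)cc12` differs from compound 3 by acetyl in place of hydrogen on a nitrogen on an aromatic ring. Among the measured compounds shown here, with no comparable step available, the change is expected to be small: a 1.2-fold lower number from compound 3 to compound 4 (0.09 log units; within the scatter), with no clear direction beyond the scatter. Compound 4 is therefore estimated at 8000 nM, between 2000 nM and 30000 nM.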

Compound 4, half-maximal inhibitory concentration: 27500 nM
Beside the measured number, compound 4's estimate is 3.4-fold (0.54 log units) below it, within the range that was stated.
By their numbers in this assay, from the lowest: compound 1; then compounds 2 and 3 (each within the scatter of the next); then compound 4.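

Replacing hydrogen with acetyl on this nitrogen, the change from amino to acetamido, gives in this assay a 2.8-fold higher number from compound 3 to compound 4 (0.45 log units; beyond the scatter) and so a weaker inhibitor. Among these compounds, this is the first single change that can be read in this set, and it shows a modest loss that lies beyond the scatter, so at this position the free amino group is preferred over acetamido. Nothing measured here explains the loss.

Going by these compounds, it remains open whether a longer acyl chain such as butanoyl, or a methanesulfonyl group on the same nitrogen, would give a similar loss. Whether acetyl would have the same effect on the core of compound 1 is also unknown.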